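The source may report more compounds than this note shows. Statements on the series, on what has been measured and on what is new or still open speak of the compounds shown alone.

Compound 1 `O=C(Oc1ccccc1)C1(S(=O)(=O)c2ccc(Oc3ccc(OC(F)(F)F)cc3)cc2)CCC2(CCNCC2)C1` and compound 2 `Nc1ccccc1NC(=O)C1(S(=O)(=O)c2ccc(Oc3ccc(OC(F)(F)F)cc3)cc2)CCC2(CCNCC2)C1` share one core and differ in a single place: phenoxy in place of (2-aminophenyl)amino on a carbonyl carbon. In a functional assay on blood (Homo sapiens), with a stated time of 60 min, in the presence of a further agent that is not named here (a lower number here means that less compound is needed, a higher number that more compound is needed for the effect), compound 2 gives 900 nM, and compound 1 gives 900 nM; the step of no change at the digits printed from compound 2 to compound 1 (within the scatter). Compound 3 `COc1ccc(S(=O)(=O)C2(C(=O)Nc3ccccc3N)CCC3(CCNCC3)C2)cc1Cl` is built on another core; the difference between the two cores is not broken down here. In this assay compound 3 gives 7500 nM, the highest of the three numbers. Compound 4 `COc1ccc(S(=O)(=O)C2(C(=O)Oc3ccccc3)CCC3(CCNCC3)C2)cc1Cl` is compound 3 carrying the same change, (phenoxy in place of (2-aminophenyl)amino on a carbonyl carbon), at the same place. Because the earlier step of no change at the digits printed from compound 2 to compound 1 (within the scatter) stayed within the scatter, a step of about the same size is expected here, no change at the digits printed from compound 3 to compound 4 (within the scatter), resting on that single pair alone. Compound 4 is therefore estimated at 7500 nM, with a likely range from 3000 nM to 19000 nM.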

Compound 4, half-maximal effective concentration: 3700 nM
Compound 4: middle estimate off by 2.0-fold (0.31 log units), on the high side; measured number inside the range.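

In this assay, putting phenoxy in place of (2-aminophenyl)amino on the carbonyl carbon gives a 2.0-fold lower number from compound 3 to compound 4 (0.31 log units; beyond the scatter). Set beside the same change on the core of compound 1, the two steps cannot be told apart: the same change on two cores in this assay, no change at the digits printed (within the scatter) from compound 2 to compound 1 and a 2.0-fold lower number (0.31 log units; beyond the scatter) from compound 3 to compound 4, 2.0-fold (0.31 log units) apart, within the scatter of two such steps On these two pairs, the change carries from one core to the other without a clear difference, but two pairs cannot show that it would behave the same way on further cores, and they do not explain why either step has its size.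

The compounds shown leave open what other groups at this position would do. A carboxylic acid in place of the phenoxycarbonyl group, for example, is not among them.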